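Proline-to-glycine ester swap on a hexokinase-2 inhibitor

A few compounds are considered here, and "the series" means these few. Any claim that something is new, unique, unknown or untested is made for them only; others in the source may bear on it.

Compound 1 `C=C1CC[C@H]2[C@@](C)(CC[C@@H](OC(=O)[C@H](N)CC(C)C)[C@@]2(C)NC=O)[C@@H]1/C=C/C1=CCOC1=O`: > 50000 nM
Compound 2 `C=C1CC[C@H]2[C@@](C)(CC[C@@H](OC(=O)[C@H]3CCCN3)[C@@]2(C)NC=O)[C@@H]1/C=C/C1=CCOC1=O`: 26100 nM

In an assay for inhibition of hexokinase-2 (Homo sapiens), read by coupled enzyme assay, with a stated time of 10 min, in the presence of a further agent that is not named here (on this read-out lower numbers stand for stronger inhibition and higher numbers for weaker inhibition), compound 1 reaches only a limit, > 50000 nM. Going by the values given here, compound 2 gives 26100 nM in this assay, the only number among the values shown. Among the compounds with values here, the step of an at least 1.9-fold lower number from compound 1 to compound 2 (0.28 log units; that floor lies within the scatter) rests on the limit of > 50000 nM in this assay, at which 1 of the 2 values shown sits, and is the sole measured step. Compound 3 `C=C1CC[C@H]2[C@@](C)(CC[C@@H](OC(=O)CN)[C@@]2(C)NC=O)[C@@H]1/C=C/C1=CCOC1=O` carries the change (aminomethyl in place of pyrrolidin-2-yl on a carbonyl carbon). Within the data shown here, no measured pair shows this swap, so a step near the scatter is expected, a 1.3-fold higher number from compound 2 to compound 3 (0.13 log units; within the scatter). Compound 3 is estimated at 35000 nM, between 12000 nM and 100000 nM.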

Compound 3, half-maximal inhibitory concentration: > 50000 nM
Compound 3: only a limit was reported; the forecaster's own chance of this, stated with the estimate: 40%; middle value at least 1.4-fold (0.15 log units) away from the limit.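

In this assay compound 3 reaches only a limit, > 50000 nM. Putting aminomethyl in place of pyrrolidin-2-yl on this carbonyl carbon gives an at least 1.9-fold higher number from compound 2 to compound 3 (0.28 log units; that floor lies within the scatter), so these values do not establish that losing the ring matters. The step between compound 1 and compound 3 cannot be read, because both rest on a limit: the limit of > 50000 nM in this assay, at which 2 of the 3 values shown sit.

On these data alone, the true value of compound 3 remains open. So does how a piperidine ring, or a longer chain ending in an amine, would read at this position.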